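Three Cytotoxicity Limits and an Untested Amide Variant

The source may hold more compounds than are shown below. What is called first, only, known or untested is meant among the compounds shown, and "the series" means these compounds.

Compound 1, `COc1ccc2nc(C)cc(OCC(=O)Nc3cc(C)ccc3C)c2c1`, gives > 100000 nM in a toxicity assay on HepG2 cells (Homo sapiens) for inhibition, read by CellTiter-Glo, with a stated time of 48 h (on this read-out higher numbers stand for weaker inhibition and lower numbers for stronger inhibition), which is a limit of the assay and not a number.
Compound 2, `COc1cccc(NC(=O)COc2cc(C)nc3ccc(OC)cc23)c1`, gives > 100000 nM in this assay, again a limit.
Compound 3, `COc1ccc(NC(=O)COc2cc(C)nc3ccc(OC)cc23)cc1`, gives > 100000 nM in this assay, again a limit.

The three compounds share one core and differ only in the aromatic group sitting on the amide-type nitrogen. Because all three rest at the limit of > 100000 nM in this assay, at which 3 of the 3 values shown sit, none of the steps between them can be read: a step that the two limits leave unreadable from compound 1 to compound 2, a step that the two limits leave unreadable from compound 1 to compound 3 and a step that the two limits leave unreadable from compound 2 to compound 3. Compound 3 therefore stands exactly where its two companions stand, at a limit rather than a measured number, and nothing in these data separates it from them.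

Compound 4, `COc1ccc2nc(C)cc(OCC(=O)Nc3cc(C)ccc3OC)c2c1`, is not yet measured. It differs from compound 3 in one place: 2-methoxy-5-methylphenyl in place of 4-methoxyphenyl on an amide-type nitrogen. For the measured compounds named here, the measured steps that bear on this change are the three above, and all are unreadable; they show only that three different aromatic groups on this nitrogen, whether methyl-bearing or methoxy-bearing, leave the read-out at its limit. The step of a number no higher from compound 3 to compound 4 (the limit leaves the size open) in this assay is therefore expected to be none beyond the scatter, with the result most likely again a limit. Compound 4 is estimated to give about 100000 nM, within 40000 nM to 300000 nM.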

Compound 4, half-maximal inhibitory concentration: > 100000 nM
Compound 4: only a limit was reported; the forecaster's own chance of this, stated with the estimate: 85%; the middle value lies on the limit itself.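

Compound 4 rests at a limit of the assay and not at a number, just as compound 1, compound 2 and compound 3 do, so none of the steps among these four compounds can be read in this assay: the limit of > 100000 nM in this assay, at which 4 of the 4 values shown sit.

The compounds shown leave open whether their aromatic groups on the amide-type nitrogen differ in effect on this read-out at all.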